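The source may report more compounds than this note shows. Statements on the series, on what has been measured and on what is new or still open speak of the compounds shown alone.

In a functional assay on NCI-H460 cells (Homo sapiens) for inhibition, read by sulforhodamine B assay, with a stated time of 48 h (on this read-out lower numbers stand for stronger inhibition of growth and higher numbers for weaker inhibition of growth), compound 1 (`O=C(NNC(=O)c1ccc2[nH]c(-c3ccc([N+](=O)[O-])o3)nc2c1)c1ccccc1`) gives 62.5 ug/mL and compound 2 (`COc1cccc(C(=O)NNC(=O)c2ccc3[nH]c(-c4ccc([N+](=O)[O-])o4)nc3c2)c1`) gives 62.5 ug/mL while compound 3 (`O=CNNC(=O)c1ccc2[nH]c(-c3ccc([N+](=O)[O-])o3)nc2c1`) gives 31.3 ug/mL in the same read-out, which places compound 3 within the scatter of both others. Compound 4 (`COc1ccc(C(=O)NNC(=O)c2ccc3[nH]c(-c4ccc([N+](=O)[O-])o4)nc3c2)cc1OC`) carries 3,4-dimethoxyphenyl in place of hydrogen on a carbonyl carbon, the change from compound 3 being 3,4-dimethoxyphenyl in place of hydrogen on a carbonyl carbon at that one place. Among the compounds with values here, two measured steps bear on this change when read in reverse: a 2.0-fold lower number from compound 1 to compound 3 (0.30 log units; within the scatter) with hydrogen in place of phenyl, and a 2.0-fold lower number from compound 2 to compound 3 (0.30 log units; within the scatter) with hydrogen in place of 3-methoxyphenyl. A third, no change at the digits printed from compound 1 to compound 2 (within the scatter) with methoxy in place of hydrogen on an aromatic carbon, covers the added methoxy. None of these goes beyond the scatter, so no step beyond it is expected in this assay here. The expected step is a 2.0-fold higher number from compound 3 to compound 4 (0.30 log units; within the scatter) and would match those seen with the other aryl groups. For compound 4 the estimated value is 62.5 ug/mL with an expected range from 31 ug/mL to 125 ug/mL in this read-out.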

Compound 4, concentration for 50% growth inhibition: 15.6 ug/mL
Compound 4: the middle estimate sits 4.0-fold (0.60 log units) above what was measured, and the stated range ends above it.
By their numbers in this assay, from the lowest: compounds 4, 3, 1 and 2 (each within the scatter of the next, the first and the last beyond it).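

In this assay, this carbonyl carbon now gives steps beyond the scatter: a 4.0-fold lower number from compound 1 to compound 4 (0.60 log units; beyond the scatter) with 3,4-dimethoxyphenyl in place of phenyl, and a 4.0-fold lower number from compound 2 to compound 4 (0.60 log units; beyond the scatter) with one further methoxy on an aromatic carbon. The earlier methoxy change gave no change at the digits printed from compound 1 to compound 2 (within the scatter) and so differs from this second one, which shows that methoxy in place of hydrogen on the aryl group does not always leave the number unmoved. Against hydrogen at the same place, a 2.0-fold lower number from compound 3 to compound 4 (0.30 log units; within the scatter) and sets no order between the two, and nothing measured accounts for any of these steps.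

Going by these compounds, whether the shift follows the number of methoxy groups or their arrangement on the aryl group stays open. Also open, on these data alone, is how a dimethylamino group or a carboxylic acid on that aryl group, or a longer alkyl chain in its place, would read in this assay.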